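This account rests on a few compounds, and the source may have more. Where it says the series, first, only, none or still open, it means among the compounds named here.

Values in a functional assay on COLO 205 cells (Homo sapiens) for inhibition, read by sulforhodamine B assay, with a stated time of 48 h, tested at 50 uM (on this read-out lower numbers stand for less inhibition of growth and higher numbers for more inhibition of growth at the one concentration tested), for the series so far
- compound 1 `COc1ccc(/C=C/C(=O)/C=C/c2ccc(OCc3cn(CCCCOc4cc(=O)oc5ccccc45)nn3)c(OC)c2)cc1OC` gives 53%
- compound 2 `COc1cc(/C=C/C(=O)/C=C/c2cccc3ccccc23)ccc1OCc1cn(CCCCOc2cc(=O)oc3ccccc23)nn1` gives 50%
- compound 3 `COc1ccccc1/C=C/C(=O)/C=C/c1ccc(OCc2cn(CCCCOc3cc(=O)oc4ccccc34)nn2)c(OC)c1` gives 47%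

Compound 3 at 47% sits within the scatter of both other measured compounds. Compound 4 `COc1cc(/C=C/C(=O)/C=C/c2cc(OC)c(OC)c(OC)c2)ccc1OCc1cn(CCCCOc2cc(=O)oc3ccccc23)nn1` carries 3,4,5-trimethoxyphenyl in place of 2-methoxyphenyl on a double-bonded chain carbon bound to a double-bonded chain carbon, and the difference counts as 3,4,5-trimethoxyphenyl in place of 2-methoxyphenyl on a double-bonded chain carbon bound to a double-bonded chain carbon. Exchanges at this same place gave a number 3 percentage points lower from compound 1 to compound 2 (within the scatter), a number 6 percentage points lower from compound 1 to compound 3 (within the scatter) and a number 3 percentage points lower from compound 2 to compound 3 (within the scatter), so no step beyond the scatter is expected in this assay. The expected step is a number 4 percentage points higher from compound 3 to compound 4 (within the scatter), an estimate only. The estimated value for compound 4 is 51%, with an expected range from 40% to 62%.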

Compound 4, percent growth inhibition at one concentration: 60%
The estimate for compound 4 lay 9 percentage points below the measured number; the range from low to high includes it.
By their numbers in this assay, from the lowest: compounds 3, 2, 1 and 4 (each within the scatter of the next, the first and the last beyond it).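

At this place, on a double-bonded chain carbon bound to a double-bonded chain carbon, the series now shows its first step beyond the scatter in this assay (a number 13 percentage points higher from compound 3 to compound 4 (beyond the scatter)), with 3,4,5-trimethoxyphenyl in place of 2-methoxyphenyl. Against naphthalen-1-yl (a number 10 percentage points higher from compound 2 to compound 4 (within the scatter)) and against the change of hydrogen to methoxy on an aromatic carbon (a number 7 percentage points higher from compound 1 to compound 4 (within the scatter)), the steps stay within the scatter, so only compound 3 and compound 4 are separated. No available measurement bears on the reason for this step.

Open, on these data alone, is how an amine or a carboxylic acid at this place would read. Also open, as far as these compounds go, is whether a longer chain elsewhere on the shared core would move the number.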